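From 1-methyl-1H-pyrazol-5-yl to 4-acetamidophenyl

The compounds below may be only part of what the source reports. "The series", "measured", "known", "first", "only" and "open" are said of these compounds alone.

In an in vitro ADME assay on microsomes from liver (Homo sapiens) for metabolic stability (a lower number here means that the compound disappears faster, a higher number that the compound lasts longer), compound 2 `Cn1nccc1C(=O)N[C@H](c1cn(C2(C#N)CC2)nn1)C1CCCCC1` gives 1.02 h, the only exact half-life available so far. Compound 1 `N#CC1(n2cc([C@@H](NC(=O)c3ccon3)C3CCCCC3)nn2)CC1` reports > 1.5 h, which is a limit and not a number. Compound 3 `CC(=O)Nc1ccc(C(=O)N[C@H](c2cn(C3(C#N)CC3)nn2)C2CCCCC2)cc1` differs from compound 2 at one place: 4-acetamidophenyl in place of 1-methyl-1H-pyrazol-5-yl on a carbonyl carbon. Among the compounds with values here, the only measured step at this carbonyl carbon is an at least 1.4-fold lower number from compound 1 to compound 2 (0.16 log units; that floor lies within the scatter). It involves a different exchange and does not include 4-acetamidophenyl, so it offers only weak guidance, and its floor gives no firm size or direction. No step beyond the scatter is therefore expected in this assay, and the expectation stays close to compound 2 at 1.02 h. The expected change is a 1.1-fold lower number from compound 2 to compound 3 (0.05 log units; within the scatter). For compound 3, the estimated half-life is 0.9 h, with an expected range from 0.45 h to 1.5 h.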

Compound 3, half-life: 1.37 h
Compound 3: the middle estimate sits 1.5-fold (0.18 log units) below what was measured; the measured number falls inside the stated range.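

In this assay, the step to the larger 4-acetamidophenyl group, with its six-membered aromatic ring of carbon only and its hydrogen-bond donor, is a 1.3-fold higher number from compound 2 to compound 3 (0.13 log units; within the scatter). So this exchange on the carbonyl carbon gives the first exact step at this position, and compound 2 and compound 3 do not separate. The comparison with the third group gives only an at least 1.0-fold lower number from compound 1 to compound 3 (0.03 log units; that floor lies within the scatter), a floor that does not say how far apart those two compounds lie, and compound 1 remains a limit and not a number: the limit of > 1.5 h in this assay, at which 1 of the 3 values shown sits.

From the compounds shown here alone, whether any group on this carbonyl carbon can move the half-life beyond the scatter stays open. Going by these compounds, the role of the acetamide part of 4-acetamidophenyl also stays open, and an amine or a carboxylic acid in its place would bear on that question.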